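The source may hold more compounds than are shown below. What is called first, only, known or untested is meant among the compounds shown, and "the series" means these compounds.

Compound 1, `CC1=NN(c2ccc(Br)cc2)C(=O)C12C=CC(=O)C=C2c1cccc(C)c1`: 45400 nM
Compound 2, `CC1=NN(c2ccc(Br)cc2)C(=O)C12C=CC(=O)C=C2c1ccc(C)cc1`: 27400 nM
Compound 3, `CC1=NN(c2ccc(Br)cc2)C(=O)C12C=CC(=O)C=C2c1ccccc1`: > 100000 nM (a limit of the assay)

All three were tested in a functional assay on A549 cells (Homo sapiens) for antiproliferative activity, read by CCK-8 assay, with a stated time of 72 h; a lower number here means a stronger inhibitor, a higher number a weaker inhibitor. Compound 1 gives 45400 nM, the higher of the two numbers reported; its nearest neighbour is compound 2, and the step of a 1.7-fold lower number from compound 1 to compound 2 (0.22 log units; within the scatter) lies within the scatter, so the two cannot be ordered. For compound 3 the assay reports only a limit, > 100000 nM. (the limit of > 100000 nM in this assay, at which 1 of the 3 values shown sits). The steps of an at least 2.2-fold higher number from compound 1 to compound 3 (0.34 log units; beyond the scatter) and an at least 3.6-fold higher number from compound 2 to compound 3 (0.56 log units; beyond the scatter) are both beyond the scatter.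

Compound 4, `CC1=NN(c2cccc(Cl)c2)C(=O)C12C=CC(=O)C=C2c1cccc(C)c1`, has not yet been measured. It differs from compound 1 in one place: 3-chlorophenyl in place of 4-bromophenyl on an amide-type nitrogen in a ring. Among the compounds with values here, none of the measured steps bears on this change; all three alter the methylphenyl group on the double-bonded ring carbon and leave the 4-bromophenyl on the amide-type nitrogen untouched. There is therefore no measured guidance for the size or direction of the step, and the expectation is for a step of a 1.1-fold lower number from compound 1 to compound 4 (0.03 log units; within the scatter), that is, nothing beyond the scatter. Compound 4 is estimated at 42000 nM, with a range from 15000 nM to 100000 nM.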

Compound 4, half-maximal inhibitory concentration: 20100 nM
The estimate for compound 4 lay 2.1-fold (0.32 log units) above the measured number, within the range that was stated.
By their numbers in this assay, from the lowest: compounds 4, 2 and 1 (each within the scatter of the next, the first and the last beyond it). At a limit, above all of these: compound 3.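

In this assay, the group on the amide-type nitrogen proves able to move the number: a 2.3-fold lower number from compound 1 to compound 4 (0.35 log units; beyond the scatter), a modest step and the only one shown at this place, as every earlier step altered the group on the double-bonded ring carbon. Going from 4-bromophenyl to 3-chlorophenyl changes both the halogen and where it sits on the phenyl ring, so this single step cannot separate the two changes, and it rests on one pair, with the 3-methylphenyl group held fixed. Nothing measured here offers a reason for the step.

From the compounds shown here alone, it remains open whether the same exchange on the amide-type nitrogen would give a similar step with the 4-methylphenyl group of compound 2 or the phenyl group of compound 3 on the double-bonded ring carbon. Also open, going by these compounds, is how this place responds to 4-chlorophenyl or 3-bromophenyl, which would pull the two changes apart, and to quite different groups, such as a phenyl ring bearing an amine or a carboxylic acid, or a longer alkyl chain.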